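The source may report more compounds than this note shows. Statements on the series, on what has been measured and on what is new or still open speak of the compounds shown alone.

Compound 1 `CC(C)(C)Cc1c(-c2ccncc2)sc(N)c1C(=O)c1ccc(Cl)cc1` gives 6% in an assay on CHO cells for displacement of a labelled ligand from adenosine receptor A3 (Homo sapiens), read by scintillation counting, tested at 10 uM; a lower number here means less inhibition, a higher number more inhibition at the concentration tested (going by the name of the read-out).
Compound 2 `CC(C)(C)Cc1c(-c2cc(F)ccc2F)sc(N)c1C(=O)c1ccc(Cl)cc1` gives 1% in this assay.
Compound 3 `CC(C)(C)Cc1c(-c2ccccc2)sc(N)c1C(=O)c1ccc(Cl)cc1` gives 1% in this assay.

Compound 3 stands level with compound 2, the two together the lowest of the three numbers, with no change at the digits printed from compound 2 to compound 3 (within the scatter) and a number 5 percentage points lower from compound 1 to compound 3 (within the scatter). Compound 4 `CC(C)(C)Cc1c(-c2cn[nH]c2)sc(N)c1C(=O)c1ccc(Cl)cc1` differs from compound 3 in one place: 1H-pyrazol-4-yl in place of phenyl on an aromatic carbon. All three measured steps change the group on that same aromatic carbon, and each stayed within the scatter: a number 5 percentage points lower from compound 1 to compound 2 (within the scatter), a number 5 percentage points lower from compound 1 to compound 3 (within the scatter), no change at the digits printed from compound 2 to compound 3 (within the scatter). Even the pyridin-4-yl of compound 1, the only measured group with a ring nitrogen, gave no step beyond the scatter. No step beyond the scatter is therefore expected here either, and the estimate for compound 4 is 4%, with a range of 0% to 15%, meaning a number 3 percentage points higher from compound 3 to compound 4 (within the scatter).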

Compound 4, a percentage reported as inhibition, at one concentration (the size of the read-out at that concentration, not a potency): 1%
The estimate for compound 4 lay 3 percentage points above the measured number; the measured number falls inside the stated range.
By their numbers in this assay, from the lowest: compounds 2, 3, 4 and 1 (each within the scatter of the next).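

In this assay, among these compounds, the result is no change at the digits printed from compound 3 to compound 4 (within the scatter) and no change at the digits printed from compound 2 to compound 4 (within the scatter) and a number 5 percentage points lower from compound 1 to compound 4 (within the scatter) for 1H-pyrazol-4-yl, a five-membered aromatic ring with a hydrogen-bond donor, a kind of group the earlier compounds did not carry on this aromatic carbon. Neither the smaller ring nor that donor gives a step beyond the scatter among these four compounds. No measurement shown explains this result. Still open, on these data alone, is whether a different kind of group on this carbon, such as an aliphatic amine or a carboxylic acid, would give a step beyond the scatter. As far as these compounds go, replacing the neopentyl or the amino group also remains open.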